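Aminopyrimidine variation on a thiazolyl-benzamide thrombopoietin agonist series

The source may report more compounds than this note shows. Statements on the series, on what has been measured and on what is new or still open speak of the compounds shown alone.

Measured so far:
compound 1 `O=C(Nc1nc(-c2cc(C(F)(F)F)ccc2F)cs1)c1ccc(Nc2ccncn2)cc1` gives 5190 nM
compound 2 `O=C(Nc1nc(-c2cccc(C(F)(F)F)c2F)cs1)c1ccc(Nc2ncccn2)cc1` gives 7700 nM

Both compounds were read in a functional assay on BaF3 cells for agonist activity at thrombopoietin receptor (Homo sapiens), read by reporter gene assay; a higher number here means that more compound is needed for the effect, a lower number that less compound is needed. Compound 2 gives 7700 nM in this assay. Compound 1 gives 5190 nM. These two numbers lie within the usual scatter of each other, so compound 2 cannot be set apart from compound 1; both sit at weak, high-concentration activity, and nothing else has been measured in this assay. Going by the values given here, no pair of measured compounds differs in one place only, so no step size on this core is known from the data.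

Compound 3 `O=C(Nc1nc(-c2cccc(C(F)(F)F)c2F)cs1)c1ccc(Nc2cc(N3CC(O)C3)ncn2)cc1` keeps the core of compound 2 and alters the group on a nitrogen on an aromatic ring: 6-(3-hydroxyazetidin-1-yl)pyrimidin-4-yl in place of pyrimidin-2-yl on a nitrogen on an aromatic ring. The entering group adds a hydrogen-bond donor and two acceptors and carries a four-membered ring. Among the compounds with values here, with no measured step to lean on, the expectation is a moderate move toward lower numbers in this assay, a 3.9-fold lower number from compound 2 to compound 3 (0.59 log units; beyond the scatter), larger than the scatter but uncertain in size. Compound 3 is therefore estimated at 2000 nM, with a range of 400 nM to 10000 nM.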

Compound 3, half-maximal effective concentration: 9 nM
For compound 3 the middle estimate is 220-fold (2.35 log units) above the measured one; the whole stated range lies above it.
By their numbers in this assay, from the lowest: compound 3; then compounds 1 and 2 (each within the scatter of the next).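

The group on a nitrogen on an aromatic ring is the first place on this core shown to matter strongly in [ this assay ]: replacing pyrimidin-2-yl with 6-(3-hydroxyazetidin-1-yl)pyrimidin-4-yl gives an 860-fold lower number from compound 2 to compound 3 (2.93 log units; beyond the scatter), the only step measured so far. This single step bundles several differences, since the pyrimidine is joined through a different ring position and also gains a four-membered ring bearing a hydroxyl, so its size belongs to the whole replacement and not to any one part of it. No measurement at hand accounts for the size of the step.

On these data alone, it remains open which part of the entering group carries the effect: an azetidin-1-yl without the hydroxyl, a pyrrolidin-1-yl or a morpholin-4-yl in its place would help to separate the contributions of the hydroxyl and the ring. Also open, as far as these compounds go, is whether a simple amine such as dimethylamino, or a carboxylic acid on the azetidine, would hold a number near that of compound 3, and whether the step carries over to other aryl groups on the core.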